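Swapping the Aromatic Group: From Compound 2 to Compound 3

The compounds below may be only part of what the source reports. "The series", "measured", "known", "first", "only" and "open" are said of these compounds alone.

Two compounds of this set share a common core and differ only in the aromatic group attached to a saturated chain carbon bound to an aromatic nitrogen. Compound 2 `O=C(OCc1ccccc1)N1CCN(C(=S)SCc2cn(Cc3ccccc3Cl)nn2)CC1` carries a 2-chlorophenyl group there. Going by the values given here, in a functional assay on MGC-803 cells (Homo sapiens) for inhibition, read by MTT assay, with a stated time of 72 h (on this read-out lower numbers stand for stronger inhibition and higher numbers for weaker inhibition), compound 2 gives 15500 nM, a weak result and the only number reported so far. Compound 1 `COc1cc(Cn2cc(CSC(=S)N3CCNCC3)nn2)cc(OC)c1OC` differs from both partners elsewhere in the molecule and, in this assay, compound 1 gives "not determined" (no result reported), so it offers no number to lean on.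

Compound 3 `COc1cc(Cn2cc(CSC(=S)N3CCN(C(=O)OCc4ccccc4)CC3)nn2)cc(OC)c1OC` is the untested partner. The change is 3,4,5-trimethoxyphenyl in place of 2-chlorophenyl on a saturated chain carbon bound to an aromatic nitrogen. Among the compounds with values here, no measured pair in this set shows this kind of exchange, so the data give no direction for it. With nothing to point either way, the step of a 1.3-fold lower number from compound 2 to compound 3 (0.11 log units; within the scatter) is expected to stay within the ordinary scatter of repeated measurements, neither clearly stronger nor clearly weaker. On that basis compound 3 is expected to give about 12000 nM in this assay, with a plausible range from 4000 nM to 40000 nM.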

Compound 3, half-maximal inhibitory concentration: 10900 nM
Estimate against measurement, compound 3: 1.1-fold (0.04 log units) above; low and high end bracket the measured number.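

In this assay, going by these compounds alone, the exchange of 2-chlorophenyl for 3,4,5-trimethoxyphenyl on a saturated chain carbon bound to an aromatic nitrogen gives a 1.4-fold lower number from compound 2 to compound 3 (0.15 log units; within the scatter) and is the first step that can be read at this position. The entering group has 12 heavy atoms against 7 and 3 hydrogen-bond acceptors against 0, yet this difference in make-up produces no change that can be told apart from ordinary measurement scatter, so neither compound ranks ahead of the other. Nothing measured here explains this outcome.

Both groups shown at this position are six-membered aromatic rings of carbon, so a different kind of group there, such as an amine, a carboxylic acid or a longer open carbon chain, remains an open case. Compound 1 differs from compound 3 by lacking the benzyloxycarbonyl group, but with compound 1 at "not determined" (no result reported) in this assay the contribution of that group to the result cannot be read.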